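A few compounds are considered here, and "the series" means these few. Any claim that something is new, unique, unknown or untested is made for them only; others in the source may bear on it.

Of the compounds shown here, three built on a shared core have been tested in a functional assay on A549 cells (Homo sapiens) for antiproliferative activity, read by MTT assay; on this read-out lower numbers stand for stronger inhibition and higher numbers for weaker inhibition. Compound 1 `Cc1cccc(Nc2nccc(-c3ccc(Br)cc3)n2)c1` gives 63200 nM in this assay, and compound 2 `COc1cccc(Nc2nccc(-c3ccc(Br)cc3)n2)c1` gives 82700 nM. The change between them is methoxy in place of methyl on an aromatic carbon, and it produced a 1.3-fold higher number from compound 1 to compound 2 (0.12 log units; within the scatter). Compound 3 `Cc1cccc(Nc2nccc(-c3ccc(Cl)cc3Cl)n2)c1` gives 18500 nM in this assay, the lowest of the three numbers, and its gaps to compound 1 and to compound 2 both lie beyond the scatter. How the core of compound 3 differs from the core of compound 1 is not broken down here.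

Compound 4 `COc1cccc(Nc2nccc(-c3ccc(Cl)cc3Cl)n2)c1` has not yet been measured in this assay. It arises from compound 3 by the same change that took compound 1 to compound 2, namely (methoxy in place of methyl on an aromatic carbon), at the same place on the ring. A step of similar size is expected here because a 1.3-fold higher number from compound 1 to compound 2 (0.12 log units; within the scatter) stayed within the scatter. On that basis compound 4 is estimated at 24000 nM, with a plausible range from 10000 nM to 55000 nM. The estimate corresponds to an expected step of a 1.3-fold higher number from compound 3 to compound 4 (0.11 log units; within the scatter).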

Compound 4, half-maximal inhibitory concentration: 32200 nM
Compound 4: the middle estimate sits 1.3-fold (0.13 log units) below what was measured; low and high end bracket the measured number.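

In this assay, methoxy in place of methyl on an aromatic carbon gave a 1.7-fold higher number from compound 3 to compound 4 (0.24 log units; within the scatter), so on the second core, as on the first, the change produced no step beyond the scatter. Set side by side, the two steps do not differ, and the change carried over from one core to the other without a detectable difference: the same change on two cores in this assay, a 1.3-fold higher number (0.12 log units; within the scatter) from compound 1 to compound 2 and a 1.7-fold higher number (0.24 log units; within the scatter) from compound 3 to compound 4, 1.3-fold (0.12 log units) apart, within the scatter of two such steps. This does not show a real shift in either direction on either core, and two cores cannot establish that the change would behave the same way on any other core in the series.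

The compounds shown leave open what other groups at the same place on the ring would do, such as an amine, a carboxylic acid or a longer chain in place of the methyl or methoxy. They also leave open whether the same small step would hold on a core carrying a nitrile or a trifluoromethyl group instead of the halogens seen here.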